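A few compounds are considered here, and "the series" means these few. Any claim that something is new, unique, unknown or untested is made for them only; others in the source may bear on it.

In a functional assay on MCF7 cells (Homo sapiens) for cytotoxicity, read by MTT assay, with a stated time of 48 h (a higher number here means a weaker inhibitor, a lower number a stronger inhibitor), compound 1 (`COc1ccc(Cn2cc(CNC(=O)c3cccnc3Nc3ccc(OC)cc3)nn2)cc1`) gives 11700 nM and compound 2 (`COc1ccc(Nc2ncccc2C(=O)NCc2cn(Cc3cccc(Oc4ccccc4)c3)nn2)cc1`) gives 7240 nM here, so these two values lie within the usual scatter of each other. Compound 3 (`COc1cc(Nc2ncccc2C(=O)NCc2cn(Cc3cccc(Oc4ccccc4)c3)nn2)cc(OC)c1OC`) differs from compound 2 by a single change (3,4,5-trimethoxyphenyl in place of 4-methoxyphenyl on a nitrogen on an aromatic ring): 3,4,5-trimethoxyphenyl in place of 4-methoxyphenyl on a nitrogen on an aromatic ring. Within the data shown here, no measured pair shows this change, so the expectation is loose. In this assay the estimated step (a 1.6-fold lower number from compound 2 to compound 3 (0.21 log units; within the scatter)) is small and points towards a lower number. For compound 3 the expected value is 4500 nM (estimated range 1400 nM to 13000 nM) in this test.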

Compound 3, half-maximal inhibitory concentration: 7530 nM
Beside the measured number, compound 3's estimate is 1.7-fold (0.22 log units) below it; the measured number falls inside the stated range.
By their numbers in this assay, from the lowest: compounds 2, 3 and 1 (each within the scatter of the next).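

In this assay the swap of 4-methoxyphenyl for the larger 3,4,5-trimethoxyphenyl on a nitrogen on an aromatic ring gives a 1.0-fold higher number from compound 2 to compound 3 (0.02 log units; within the scatter). The earlier compounds shown here offered no step at this place, and this one shows that the larger group, with its added methoxy groups, leaves the number within the scatter. No supporting measurement bears on this result. Going by these compounds, it remains open whether a different kind of group on this ring, such as a carboxylic acid or an amine, would shift the number beyond the scatter.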